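Ring Expansion at the Piperidine Nitrogen Substituent

The source may report more compounds than this note shows. Statements on the series, on what has been measured and on what is new or still open speak of the compounds shown alone.

Of the compounds shown here, three sharing one core have been measured in a functional assay on isolated protein for agonist activity at Glucose-dependent insulinotropic receptor (Homo sapiens), read by HTRF and cAMP accumulation; a higher number here means that more compound is needed for the effect, a lower number that less compound is needed. Compound 1 `C[C@@H](CF)OC(=O)N1CCC(O[C@H]2CC[C@H](Oc3cnc(S(C)(=O)=O)cn3)CC2)CC1` gives 31.1 nM. Compound 2 `CS(=O)(=O)c1cnc(O[C@H]2CC[C@H](OC3CCN(C(=O)C4(C(F)(F)F)CCCC4)CC3)CC2)cn1` gives 38.4 nM. Compound 3 `CS(=O)(=O)c1cnc(O[C@H]2CC[C@H](OC3CCN(CC4(C(F)(F)F)CCC4)CC3)CC2)cn1` gives 54.8 nM. Among these three numbers compound 3 has the largest, yet the gaps are small: a 1.4-fold higher number from compound 2 to compound 3 (0.15 log units; within the scatter), and a 1.8-fold higher number from compound 1 to compound 3 (0.25 log units; within the scatter). The remaining pair is also close, a 1.2-fold higher number from compound 1 to compound 2 (0.09 log units; within the scatter). In short, the three compounds cannot be told apart in this assay.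

Compound 4 `CS(=O)(=O)c1cnc(O[C@H]2CC[C@H](OC3CCN(CC4(C(F)(F)F)CCCC4)CC3)CC2)cn1` is the next step. Relative to compound 3 the change is a group of 9 heavy atoms (6 carbon, 3 fluorine; one five-membered non-aromatic ring of carbon only) in place of a group of 8 heavy atoms (5 carbon, 3 fluorine; one four-membered non-aromatic ring of carbon only), on a saturated chain carbon bound to an amine nitrogen in a ring. This is a ring enlargement by one carbon on the group hanging from the piperidine nitrogen. Within the data shown here, no measured pair isolates exactly this change; the closest is the step from compound 2 to compound 3, which swapped a cyclopentyl-bearing carbonyl for a cyclobutyl-bearing methylene and stayed within the scatter, and the other two steps, which altered this region more heavily, also stayed within the scatter. The expectation for compound 4 is therefore no shift beyond the scatter, expressed as a 1.2-fold lower number from compound 3 to compound 4 (0.09 log units; within the scatter). Compound 4 is estimated at 45 nM in this assay, with a range from 20 nM to 110 nM.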

Compound 4, half-maximal effective concentration: 48.8 nM
Compound 4: middle estimate off by 1.1-fold (0.04 log units), on the low side; measured number inside the range.
By their numbers in this assay, from the lowest: compounds 1, 2, 4 and 3 (each within the scatter of the next).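

Among these compounds, the step from the 1-(trifluoromethyl)cyclobutyl group to its five-membered ring counterpart, on a saturated chain carbon bound to an amine nitrogen in a ring, gives a 1.1-fold lower number from compound 3 to compound 4 (0.05 log units; within the scatter) in this assay and is the first pair here to isolate ring size alone. With the five-membered ring kept, the pair with and without the carbonyl gives a 1.3-fold higher number from compound 2 to compound 4 (0.10 log units; within the scatter) and so shows that this carbonyl can be exchanged without a shift beyond the scatter. Even the larger exchange for the ringless fluorinated group of compound 1 gives a 1.6-fold higher number from compound 1 to compound 4 (0.20 log units; within the scatter) and so all four compounds remain indistinguishable in this assay, with no ring size or linking group standing out at this position. Nothing available explains why these groups give such similar numbers.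

Still open, on these data alone, is whether the same holds for a six-membered carbon ring, or for a methyl group or a nitrile in place of the trifluoromethyl. The compounds shown also leave unanswered how an amine or a carboxylic acid on this substituent would read in this assay.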